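The compounds below may be only part of what the source reports. "The series", "measured", "known", "first", "only" and "open" are said of these compounds alone.

Measured so far in a functional assay on K562 cells (Homo sapiens) for cytotoxicity, read by MTT assay, with a stated time of 24 h; on this read-out lower numbers stand for stronger inhibition and higher numbers for weaker inhibition:
Compound 1 `COc1cc(/C=C2\CN(C)C/C(=C\c3ccc(Br)cc3)C2=O)cc(OC)c1OC`: 12400 nM
Compound 2 `COc1cc(/C=C2\CN(C)C/C(=C\c3ccc(Cl)c(Cl)c3)C2=O)cc(OC)c1OC`: 16200 nM
Compound 3 `CN1C/C(=C\c2ccc(F)cc2)C(=O)/C(=C/c2cccc([N+](=O)[O-])c2)C1`: 11300 nM

Compound 3, at 11300 nM, sits within the usual scatter of both compound 1 and compound 2, so these three numbers cannot be put in a firm order.

The next compound, compound 4 `CN1C/C(=C\c2cccc(Br)c2)C(=O)/C(=C/c2cccc([N+](=O)[O-])c2)C1`, differs from compound 3 in one group: 3-bromophenyl in place of 4-fluorophenyl on a double-bonded chain carbon bound to a double-bonded ring carbon. In words, 3-bromophenyl takes the place of 4-fluorophenyl on a double-bonded chain carbon bound to a double-bonded ring carbon.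

Among the compounds with values here, only one measured step bears on this, a swap of one halogen-carrying phenyl group for another on the same kind of carbon: a 1.3-fold higher number from compound 1 to compound 2 (0.12 log units; within the scatter). That step stays within the scatter. Within the data shown here, it is only a loose guide, though, since compound 1 and compound 2 also differ from compound 3 in another part of the structure, and no measured compound carries 3-bromophenyl.

Resting on compound 3 at 11300 nM and on the size of that one step, no change beyond the scatter is expected in this assay. The estimated step is a 1.0-fold higher number from compound 3 to compound 4 (0.01 log units; within the scatter). Compound 4 is therefore expected at 11500 nM, with an estimated range from 6000 nM to 22000 nM.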

Compound 4, half-maximal inhibitory concentration: 12200 nM
Compound 4: the middle estimate sits 1.1-fold (0.03 log units) below what was measured, within the range that was stated.
By their numbers in this assay, from the lowest: compounds 3, 4, 1 and 2 (each within the scatter of the next).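

Within the data shown here, with the rest of the structure held fixed, this is the first direct look at this place on a double-bonded chain carbon bound to a double-bonded ring carbon: in this assay there is a 1.1-fold higher number from compound 3 to compound 4 (0.03 log units; within the scatter), which stays within the scatter. The exchange alters both the halogen and its location on the phenyl ring, yet it does not move the number beyond the scatter, and neither does the other swap of halogen-carrying phenyl groups, with a 1.3-fold higher number from compound 1 to compound 2 (0.12 log units; within the scatter), so neither of the two measured swaps goes against this limited picture. No measured property of these groups is available to account for this result.

As far as these compounds go, because fluorine and bromine changed together with their location, the effect of either change alone remains unknown, and a matched pair carrying 4-bromophenyl and 3-bromophenyl with the same group on the other side would separate them. From the compounds shown here alone, every group compared here is a halogen-carrying phenyl ring, so it remains open whether a phenyl ring carrying an amine or a carboxylic acid, or a longer alkyl chain in its place, would give a number beyond the scatter.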